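The compounds below may be only part of what the source reports. "The series", "measured", "known", "first", "only" and "open" are said of these compounds alone.

Compounds measured in a functional assay on the whole organism with Mus musculus as the target, with a stated time of 20 min; on this read-out higher numbers stand for an effect only at larger amounts of compound and lower numbers for an effect already at smaller amounts:

compound 1 `CC(C)S(=O)(=O)N(C)c1ccc(NC(=O)c2ccccc2)cc1` gives 0.01 mg/kg
compound 2 `CC(C)S(=O)(=O)Nc1ccc(NC(=O)c2ccccc2)cc1` gives 10 mg/kg
compound 3 `CC(C)S(=O)(=O)Nc1ccc(N(C)S(=O)(=O)c2ccc(F)cc2)cc1` gives 0.1 mg/kg

Compound 1 and compound 2 differ in one place: hydrogen in place of methyl on a sulfonamide nitrogen. This change made the step of a 1000-fold higher number from compound 1 to compound 2 (3.00 log units; beyond the scatter). Compound 3 carries a different core; how its core differs from that of compound 1 is not broken down here. Compound 3 stands between the two: its number is higher than that of compound 1 and lower than that of compound 2, both gaps beyond the scatter.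

Compound 4 `CC(C)S(=O)(=O)Nc1ccc(NS(=O)(=O)c2ccc(F)cc2)cc1` has not yet been measured in this assay. It differs from compound 3 by hydrogen in place of methyl on a sulfonamide nitrogen, and the place of the change is the same word for word as in the step from compound 1 to compound 2. He therefore expects compound 4 to follow the same kind of move, an estimated step of a 300-fold higher number from compound 3 to compound 4 (2.48 log units; beyond the scatter), because the one measured example of this change, a 1000-fold higher number from compound 1 to compound 2 (3.00 log units; beyond the scatter), was large and beyond the scatter, though a single example gives only a rough guide. On that basis he estimates compound 4 at 30 mg/kg, most likely between 3 mg/kg and 300 mg/kg.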

Compound 4, minimum effective dose: 1 mg/kg
For compound 4 the middle estimate is 30-fold (1.48 log units) above the measured one, outside the stated range (below it).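

Putting hydrogen in place of methyl on a sulfonamide nitrogen again moved the result in the same direction in this assay, giving a 10-fold higher number from compound 3 to compound 4 (1.00 log units; beyond the scatter). The direction held on both cores shown, but the size of the step did not carry over: the same change on two cores in this assay, a 1000-fold higher number (3.00 log units; beyond the scatter) from compound 1 to compound 2 and a 10-fold higher number (1.00 log units; beyond the scatter) from compound 3 to compound 4, 100-fold (2.00 log units) apart, beyond the scatter of two such steps. In this series, then, the earlier step predicts the direction on the core of compound 3 but not the size, and these two pairs do not show which feature of the cores sets that size or how the change would behave on a third core.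

The compounds shown leave open how an ethyl group or a longer chain on that sulfonamide nitrogen would compare with methyl and hydrogen. They also leave open whether the step on the core of compound 3 would stay the same if chlorine or a methoxy group stood in place of the fluorine.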